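The source may hold more compounds than are shown below. What is called first, only, known or untested is meant among the compounds shown, and "the series" means these compounds.

Of the compounds shown here, three from one series have been tested in a functional assay on KB cells (Homo sapiens) for cytotoxicity, read by sulforhodamine B assay; on this read-out lower numbers stand for an effect already at smaller amounts and higher numbers for an effect only at larger amounts of compound. Compound 1 `C=C1CC[C@@H]2[C@](C)(CO[Si](c3ccccc3)(c3ccccc3)C(C)(C)C)[C@H](OC(C)=O)CC[C@@]2(C)[C@@H]1C/C=C1/C(=O)OC[C@H]1O` gives 9.86 uM. Compound 3 `C=C1CC[C@@H]2[C@](C)(CO[Si](c3ccccc3)(c3ccccc3)C(C)(C)C)[C@H](OC(C)=O)CC[C@@]2(C)[C@@H]1C/C=C1/C(=O)OC[C@H]1OC(C)=O` differs from compound 1 by acetyl in place of hydrogen on an oxygen on a saturated carbon. In this assay compound 3 gives 29 uM, so the step of a 2.9-fold higher number from compound 1 to compound 3 (0.47 log units; beyond the scatter). Compound 2 `C=C1CC[C@@H]2[C@](C)(CO[Si](C)(C)C(C)(C)C)[C@H](O)CC[C@@]2(C)[C@@H]1C/C=C1/C(=O)OC[C@H]1O` gives 40.7 uM; how the core of compound 2 differs from the core of compound 1 is not broken down here, the two differing in more than one place.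

Compound 4 `C=C1CC[C@@H]2[C@](C)(CO[Si](C)(C)C(C)(C)C)[C@H](OC(C)=O)CC[C@@]2(C)[C@@H]1C/C=C1/C(=O)OC[C@H]1O` has not yet been measured. Among the measured compounds shown here, it differs from compound 2 by acetyl in place of hydrogen on an oxygen on a saturated carbon, the same change, at the same kind of place, as the one that led from compound 1 to compound 3. If that step carried over, compound 4 would be expected to land at a higher number than compound 2, and the estimate for compound 4 in this assay is 100 uM, with a likely range from 40 uM to 250 uM. For the measured compounds named here, that expectation rests on the single earlier step of a 2.9-fold higher number from compound 1 to compound 3 (0.47 log units; beyond the scatter) and on compound 2 giving 40.7 uM; the expected step is a 2.5-fold higher number from compound 2 to compound 4 (0.39 log units; beyond the scatter). Whether the change repeats on a different core remains to be seen.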

Compound 4, concentration for half-maximal effect: 11.2 uM
Compound 4: the middle estimate sits 8.9-fold (0.95 log units) above what was measured, and the stated range ends above it.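

In this assay, placing an acetyl on the oxygen gave a 3.6-fold lower number from compound 2 to compound 4 (0.56 log units; beyond the scatter), so the change did not keep its direction when carried to a different core. Set beside the earlier step, this gap is too large to be put down to ordinary variation between repeated measurements, which means that the result of turning hydroxy into acetoxy depends on the core in this series: the same change on two cores in this assay, a 2.9-fold higher number (0.47 log units; beyond the scatter) from compound 1 to compound 3 and a 3.6-fold lower number (0.56 log units; beyond the scatter) from compound 2 to compound 4, 11-fold (1.03 log units) apart, beyond the scatter of two such steps The cores differ in more than one place, and these two steps do not show which of those differences matters; nor do two steps give a rule for predicting the change on any further core.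

The compounds shown leave open whether a longer acyl chain such as butanoyl, or a benzoyl group, on the same oxygen would shift the number in the same direction as acetyl on each core. They also leave open what an amine in place of the hydroxy would do in this assay.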